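Phenyl in Place of Hydroxy on the Piperidinyl Tail

The compounds below may be only part of what the source reports. "The series", "measured", "known", "first", "only" and "open" are said of these compounds alone.

Compound 1 `COc1cc2c(Nc3ccc(C#N)cc3)ncnc2cc1OCCCN(C)C` and compound 2 `COc1cc2c(Nc3ccc(C#N)cc3)ncnc2cc1OCCCN1CCC(O)CC1` share the same core and differ only in the amine at the end of the side chain. In a functional assay on SH-SY5Y cells (Homo sapiens) for antiproliferative activity, read by MTT assay, with a stated time of 72 h (a higher number here means a weaker inhibitor, a lower number a stronger inhibitor), compound 1 gives 34900 nM. Compound 2 reaches only the limit of this assay, at > 100000 nM, so no number is available for it. Within the data shown here, the one measured step, an at least 2.8-fold higher number from compound 1 to compound 2 (0.45 log units; beyond the scatter), therefore tells only that compound 2 stands at or beyond (the limit of > 100000 nM in this assay, at which 1 of the 2 values shown sits), and any comparison with it starts from that limit rather than from a value.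

Compound 3 `COc1cc2c(Nc3ccc(C#N)cc3)ncnc2cc1OCCCN1CCC(c2ccccc2)CC1` keeps the piperidinyl tail of compound 2 and changes its substituent: phenyl in place of hydroxy on a saturated ring carbon. Among the measured compounds shown here, no measured step in this set involves a phenyl on the ring, so the step from compound 1 to compound 2 gives no more than a starting point. With compound 2 already at the limit, compound 3 is expected to sit around the same level, with the step of an at least 1.4-fold lower number from compound 2 to compound 3 (0.15 log units; that floor lies within the scatter), which is within the scatter. On that basis the estimate for compound 3 in this assay is 70000 nM, with a range from 20000 nM to 300000 nM.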

Compound 3, half-maximal inhibitory concentration: 7770 nM
The estimate for compound 3 lay 9.0-fold (0.95 log units) above the measured number, and the stated range ends above it.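

In this assay, the saturated ring carbon three ring bonds from the ring nitrogen proves sensitive to what it carries: phenyl in place of hydroxy gives an at least 12-fold lower number from compound 2 to compound 3 (1.10 log units; beyond the scatter). That step is only a floor, since compound 2 stands at a limit of the assay and not at a number: the limit of > 100000 nM in this assay, at which 1 of the 3 values shown sits.

Replacing dimethylamino with a piperidinyl tail therefore does not by itself weaken the compound, as the 4-phenylpiperidin-1-yl tail gives a 4.5-fold lower number from compound 1 to compound 3 (0.65 log units; beyond the scatter), while the 4-hydroxypiperidin-1-yl tail gives an at least 2.8-fold higher number from compound 1 to compound 2 (0.45 log units; beyond the scatter), so the two steps from compound 1 run in opposite directions depending on the group on the ring.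

The compounds shown leave open whether the change comes from the aromatic ring itself or from the loss of hydroxy, a question that an unsubstituted piperidine or a cyclohexyl group on the same carbon would help to settle. They also leave open whether a benzyl group, a phenyl ring bearing fluorine or a longer chain to the amine would lower the number further.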